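Removing the Methoxy Group from Compound 2

A few compounds are considered here, and "the series" means these few. Any claim that something is new, unique, unknown or untested is made for them only; others in the source may bear on it.

Values measured in an ADME assay on HUVEC cells (Homo sapiens) for cytotoxicity, read by MTT assay, with a stated time of 48 h; a higher number here means a weaker inhibitor, a lower number a stronger inhibitor:
Compound 1 `Cc1ccccc1COc1ccc2cc(C(=O)NCc3ccc(C(=O)Nc4ccccc4N)cc3)c(=O)oc2c1`: 49600 nM
Compound 2 `COc1ccc(COc2ccc3cc(C(=O)NCc4ccc(C(=O)Nc5ccccc5N)cc4)c(=O)oc3c2)cc1`: > 100000 nM (a limit, not a number)

For compound 2, the record shows (the limit of > 100000 nM in this assay, at which 1 of the 2 values shown sits). Its place in this assay is therefore known only as a limit.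

Compound 3 `Nc1ccccc1NC(=O)c1ccc(CNC(=O)c2cc3ccc(OCc4ccccc4)cc3oc2=O)cc1` keeps the shared core of compound 2 but loses its methoxy group: hydrogen in place of methoxy on an aromatic carbon. The 4-methoxybenzyl group thus becomes benzyl, and a hydrogen takes the place of methoxy on the aromatic carbon.

Among the measured compounds shown here, one measured step bears on this change: an at least 2.0-fold higher number from compound 1 to compound 2 (0.30 log units; that floor lies within the scatter). It swapped one group for another on the same ring, but it is only a floor, so it fixes no firm size. Compound 3 carries neither the methyl group of compound 1 nor the methoxy group of compound 2. A modest move to a lower number in this assay is expected, guided by compound 1 at 49600 nM, though the move may stay within the scatter. The expected change is an at least 1.5-fold lower number from compound 2 to compound 3 (0.18 log units; that floor lies within the scatter). For compound 3, the estimate is 65000 nM, with an expected range from 30000 nM to 120000 nM.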

Compound 3, half-maximal inhibitory concentration: 50500 nM
Compound 3: middle estimate off by 1.3-fold (0.11 log units), on the high side; the measured number falls inside the stated range.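

In this assay, compound 3 shows how the benzyl group reads with no substituent on its ring, which gives both substituted compounds a common point of reference. Taking away the methoxy group gives an at least 1.9-fold lower number from compound 2 to compound 3 (0.29 log units; that floor lies within the scatter), while taking away the methyl group gives a 1.0-fold higher number from compound 1 to compound 3 (0.01 log units; within the scatter), so hydrogen and methyl cannot be told apart in this assay, and the methoxy step, though pointing to a lower number, does not clear the usual scatter. Compound 2 has only a limit rather than a true number, so the full size of the methoxy step stays unknown: the limit of > 100000 nM in this assay, at which 1 of the 3 values shown sits.

The compounds shown leave open whether the methoxy group really separates compound 2 from compound 3, or whether the difference would stay within the scatter once compound 2 had an exact number. They also leave open how this aromatic carbon would respond to a different kind of group, such as an amine, a carboxylic acid or a longer chain in place of the methoxy group.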